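Replacing a Heteroaryl Group on the Ring Nitrogen in Compound 4

The source may hold more compounds than are shown below. What is called first, only, known or untested is meant among the compounds shown, and "the series" means these compounds.

Compound 1 `Nc1ccccc1NC(=O)c1ccc(CSC(=S)N2CCN(c3ccncc3)CC2)cc1`: 90.7%
Compound 2 `Nc1ccccc1NC(=O)c1ccc(CSC(=S)N2CCN(c3cnccn3)CC2)cc1`: 85.8%
Compound 3 `Nc1ccccc1NC(=O)c1ccc(CSC(=S)N2CCN(Cc3cccnc3)CC2)cc1`: 89.2%

In a functional assay on A-375 cells (Homo sapiens) for antiproliferative activity, read by CCK-8 assay, with a stated time of 72 h, tested at 8 uM (a lower number here means a weaker effect, a higher number a stronger effect of the compound at the concentration tested), compound 3 stands second highest of the three numbers. Its neighbours sit close: a number 1.5 percentage points lower from compound 1 to compound 3 (within the scatter) and a number 3.4 percentage points higher from compound 2 to compound 3 (within the scatter), so all three compounds are within the scatter of one another.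

Compound 4 `Cc1ccc(N2CCN(C(=S)SCc3ccc(C(=O)Nc4ccccc4N)cc3)CC2)cc1` differs from compound 3 in one place: 4-methylphenyl in place of (pyridin-3-yl)methyl on an amine nitrogen in a ring. All three measured steps also exchange the group on that same ring nitrogen, and each stayed within the scatter, including a number 4.9 percentage points lower from compound 1 to compound 2 (within the scatter). On that basis no step beyond the scatter is expected for compound 4, though the entering group is of a kind not yet tested, so the range is widened. Compound 4 is estimated at 85% (range 70% to 95%), an expected step of a number 4.2 percentage points lower from compound 3 to compound 4 (within the scatter).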

Compound 4, a percentage reported as inhibition, at one concentration (the size of the read-out at that concentration, not a potency): 26.4%
Compound 4: the middle estimate sits 58.6 percentage points above what was measured; measured number outside the range, below it.
By their numbers in this assay, from the lowest: compound 4; then compounds 2, 3 and 1 (each within the scatter of the next).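

At the ring nitrogen, the group is not freely exchangeable: in this assay 4-methylphenyl brings a number 62.8 percentage points lower from compound 3 to compound 4 (beyond the scatter) and a number 59.4 percentage points lower from compound 2 to compound 4 (beyond the scatter) and a number 64.3 percentage points lower from compound 1 to compound 4 (beyond the scatter) even though the three earlier groups lie within the scatter of one another. The entering group matches (pyridin-3-yl)methyl in heavy atoms, yet its ring is carbon only and it has no hydrogen-bond acceptor. Nothing available explains the loss.

Still open, on these data alone, is whether the loss follows the absent ring nitrogen or the added methyl. A plain phenyl, a benzyl or a 4-methoxyphenyl group at this ring nitrogen would help to separate the two.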